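The source may hold more compounds than are shown below. What is called first, only, known or untested is meant among the compounds shown, and "the series" means these compounds.

Measured in a functional assay on A-431 cells (Homo sapiens) for cytotoxicity, read by MTT assay, with a stated time of 72 h, tested at 3 uM; a higher number here means more inhibition of growth at the concentration tested, a lower number less inhibition of growth:
- compound 1 `N/C(=N\NC(=S)N1CCOCC1)c1ccccn1` gives 43.1%
- compound 2 `Cc1ccnc(/C(N)=N/NC(=S)N2CCOCC2)c1` gives 35.5%
- compound 3 `N/C(=N\NC(=S)N1CCSCC1)c1ccccn1` gives 37.2%

Compound 1 has the highest of the three numbers, but its steps to the others, a number 7.6 percentage points lower from compound 1 to compound 2 (within the scatter) and a number 5.9 percentage points lower from compound 1 to compound 3 (within the scatter), both stay within the scatter, so the three compounds cannot be ordered. Compound 4 `Cc1cccc(/C(N)=N/NC(=S)N2CCOCC2)n1` differs from compound 1 by methyl in place of hydrogen on an aromatic carbon, at the place next to the ring nitrogen. The step that bears on it is the other methyl step, from compound 1 to compound 2, which was small and within the scatter; the change from compound 1 to compound 3 concerns a different part of the molecule. No step beyond the scatter is therefore expected in this assay. Compound 4 is estimated at 38%, with a range from 25% to 51%, meaning an expected step of a number 5.1 percentage points lower from compound 1 to compound 4 (within the scatter).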

Compound 4, percent growth inhibition at one concentration: 45.8%
For compound 4 the middle estimate is 7.8 percentage points below the measured one; low and high end bracket the measured number.
By their numbers in this assay, from the lowest: compounds 2, 3, 1 and 4 (each within the scatter of the next, the first and the last beyond it).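

In this assay, methyl in place of hydrogen next to the ring nitrogen gives a number 2.7 percentage points higher from compound 1 to compound 4 (within the scatter), so this position accepts the group without a readable change. Yet compound 2 at 35.5% and compound 4 at 45.8% lie beyond the scatter of each other, though each lies within it of compound 1, so where the methyl sits on the ring may matter. Nothing available explains this gap. On these data alone, whether an ethyl chain, an amine or a carboxylic acid would be accepted at this place stays open, as does whether the methyl would give the same result with thiomorpholin-4-yl in place of morpholin-4-yl.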